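Nitro for Methyl: Cytotoxicity Across Three Analogues

The source may hold more compounds than are shown below. What is called first, only, known or untested is meant among the compounds shown, and "the series" means these compounds.

Compound 1 `Cc1cccc(C(=O)N(C(=S)OCCN2C(=O)c3ccccc3C2=O)c2ccc(Cl)cc2)c1`: 58000 nM
Compound 2 `O=C1c2ccccc2C(=O)N1CCOC(=S)N(C(=O)c1cccc([N+](=O)[O-])c1)c1ccc(Cl)cc1`: 18000 nM
Compound 3 `Cc1ccc(C(=O)N(C(=S)OCCN2C(=O)c3ccccc3C2=O)c2ccc(C)cc2)cc1`: 83000 nM

Of the compounds shown here, three have been measured in an ADME assay on MT4 cells (Homo sapiens) for cytotoxicity, read by MTT assay; on this read-out higher numbers stand for lower toxicity in this test and lower numbers for higher toxicity in this test. Compound 2 differs from compound 1 by nitro in place of methyl on an aromatic carbon; in this assay that change gave a 3.2-fold lower number from compound 1 to compound 2 (0.51 log units; beyond the scatter). Compound 3 and compound 1 lie within the scatter of each other, while compound 3 lies beyond it from compound 2. The difference between the cores of compound 3 and compound 1 is not broken down here.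

Compound 4 `Cc1ccc(N(C(=O)c2ccc([N+](=O)[O-])cc2)C(=S)OCCN2C(=O)c3ccccc3C2=O)cc1` has not yet been measured. It differs from compound 3 by nitro in place of methyl on an aromatic carbon. This is the same kind of change as that from compound 1 to compound 2, not the same: there the nitro sits meta to a large group, here para to a large group. Resting on a 3.2-fold lower number from compound 1 to compound 2 (0.51 log units; beyond the scatter), a step of similar size is expected for compound 4, namely a 3.2-fold lower number from compound 3 to compound 4 (0.50 log units; beyond the scatter). Compound 4 is thus estimated at 26000 nM, with a range from 10000 nM to 65000 nM expected.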

Compound 4, half-maximal cytotoxic concentration: 58000 nM
Beside the measured number, compound 4's estimate is 2.2-fold (0.35 log units) below it, and the stated range covers the measured number.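

In this assay, nitro in place of methyl gave a 1.4-fold lower number from compound 3 to compound 4 (0.16 log units; within the scatter), a step that cannot be told apart from repeat-measurement scatter on this core. The two steps are consistent with one shared step size, but this does not establish that the change carries over unchanged, as only the first lies beyond the scatter and the two pairs also differ in their cores and in where the nitro sits. Among the compounds shown here, with only two pairs, the comparison cannot separate these influences, and the gap between the steps does not exceed what two such measurements can produce: the same change on two cores in this assay, a 3.2-fold lower number (0.51 log units; beyond the scatter) from compound 1 to compound 2 and a 1.4-fold lower number (0.16 log units; within the scatter) from compound 3 to compound 4, 2.3-fold (0.35 log units) apart, within the scatter of two such steps.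

The compounds shown leave open how an amine, a nitrile or a carboxylic acid in place of the methyl would read in this assay. They also leave open whether the nitro step would hold on further cores.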